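The source may report more compounds than this note shows. Statements on the series, on what has been measured and on what is new or still open speak of the compounds shown alone.

Of the compounds shown here, two sharing one core have been measured in an assay on isolated protein for inhibition of cathepsin S (Homo sapiens), read by fluorescence, with a stated time of 20 min; a higher number here means a weaker inhibitor, a lower number a stronger inhibitor. Compound 1 `N#CC1(NC(=O)[C@@H]2C[C@@H](S(=O)(=O)c3ccccc3)C[C@H]2C(=O)N2CCCCC2)CC1` carries a piperidin-1-yl group on a carbonyl carbon, and in this assay compound 1 gives 0.8 nM. Compound 2 `N#CC1(NC(=O)[C@@H]2C[C@@H](S(=O)(=O)c3ccccc3)C[C@H]2C(=O)Nc2ccc(F)cc2)CC1` carries a (4-fluorophenyl)amino group on that carbonyl carbon instead, and in this assay compound 2 gives 26 nM. Within the data shown here, that single swap is the only step recorded so far: a 33-fold higher number from compound 1 to compound 2 (1.51 log units; beyond the scatter). Compound 2 therefore stands as the higher of the two numbers, the weaker inhibitor of the pair.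

Compound 3 `N#CC1(NC(=O)[C@@H]2C[C@@H](S(=O)(=O)c3ccccc3)C[C@H]2C(=O)N2CCCC2)CC1` has not yet been measured. It differs from compound 2 in one place: pyrrolidin-1-yl in place of (4-fluorophenyl)amino on a carbonyl carbon. The recorded step bears directly on this change, because a 33-fold higher number from compound 1 to compound 2 (1.51 log units; beyond the scatter) shows how strongly the number rose when a non-aromatic ring with one hetero atom gave way to (4-fluorophenyl)amino, and pyrrolidin-1-yl is again a non-aromatic ring with one hetero atom, a close relative of piperidin-1-yl. A large fall in this assay is therefore expected, roughly reversing that step, estimated as a 17-fold lower number from compound 2 to compound 3 (1.24 log units; beyond the scatter). Compound 3 is expected to give about 1.5 nM, within a range from 0.5 nM to 5 nM.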

Compound 3, half-maximal inhibitory concentration: 2 nM
Beside the measured number, compound 3's estimate is 1.3-fold (0.12 log units) below it; low and high end bracket the measured number.
By their numbers in this assay, from the lowest: compound 1; then compound 3; then compound 2.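

In this assay, putting pyrrolidin-1-yl on the carbonyl carbon gives a 13-fold lower number from compound 2 to compound 3 (1.11 log units; beyond the scatter), so the low number of compound 1 is not unique to piperidin-1-yl: a second non-aromatic ring with one hetero atom also sits far below compound 2. The choice between these two rings still matters, but much less, since replacing piperidin-1-yl with pyrrolidin-1-yl gives a 2.5-fold higher number from compound 1 to compound 3 (0.40 log units; beyond the scatter), a modest step that remains beyond the scatter. No measurement is available that explains either step.

Compound 2 differs from the two ring compounds both in its aromatic ring and in its amide hydrogen, and the compounds shown cannot tell which of these goes with its higher number; a methyl(4-fluorophenyl)amino group, which keeps the aromatic ring but has no amide hydrogen, would help to separate them. From the compounds shown here alone, it also remains open how far the low numbers extend to other groups on this carbonyl carbon, such as dimethylamino, which has no ring at all, or morpholin-4-yl, which has a ring oxygen as well as the nitrogen.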